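Turning the double bond: compound 2 to compound 3

The source may hold more compounds than are shown below. What is called first, only, known or untested is meant among the compounds shown, and "the series" means these compounds.

Measured so far in a toxicity assay on the whole organism (strain Icem-CET (SPF Caw)) for cytotoxicity, with Mus musculus as the target; a lower number here means that less compound is needed, a higher number that more compound is needed for the effect:
- compound 1, `C/C(C(=O)NC1CC1)=C(/C)c1ccc(Cl)cc1`, gives 350 mg/kg
- compound 2, `C/C(C(=O)NC1CC1)=C(/C)c1ccc(C)cc1`, gives 110 mg/kg

Compound 2 stands at the lowest of the two numbers in this assay; its nearest neighbour is compound 1, reached by a 3.2-fold lower number from compound 1 to compound 2 (0.50 log units; beyond the scatter) with methyl in place of chloro on an aromatic carbon. Compound 3, `C/C(C(=O)NC1CC1)=C(\C)c1ccc(C)cc1`, keeps every atom and bond of compound 2: the two compounds have the same atoms and bonds and differ only in configuration as drawn: 1 of 1 stereo elements differ; a double bond is drawn E in compound 2 and Z in compound 3. Among the measured compounds shown here, no measured step concerns the geometry of the double bond; the single step between compound 1 and compound 2 changes a substituent on the aromatic ring and so says nothing about how the drawn configuration moves the number in this assay. For the measured compounds named here, with no bearing step, the change from compound 2 to compound 3 is expected to be a 1.1-fold higher number from compound 2 to compound 3 (0.04 log units; within the scatter), that is, none beyond the scatter. Compound 3 is therefore estimated at 120 mg/kg, within a range from 40 mg/kg to 350 mg/kg.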

Compound 3, dose for half-maximal effect: 280 mg/kg
For compound 3 the middle estimate is 2.3-fold (0.37 log units) below the measured one; low and high end bracket the measured number.
By their numbers in this assay, from the lowest: compound 2; then compounds 3 and 1 (each within the scatter of the next).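

In this assay, the drawn geometry of the double bond proves to matter: going from E to Z gives a 2.5-fold higher number from compound 2 to compound 3 (0.41 log units; beyond the scatter). Among the compounds shown here, the earlier step concerned only the substituent on the aromatic ring, so this is the first sign that configuration alone can move the number beyond the scatter. The step can be assigned to the double-bond geometry and to no other part of the structure because of one fact: the fact that compounds 2 and 3 differ only in the configuration as drawn

On these data alone, it remains open whether turning the double bond would give a step of similar size and direction in compound 1, which carries chloro rather than methyl. Also open, as far as these compounds go, is how the number would respond to a carboxylic acid or a longer chain in place of the methyl on the aromatic carbon, in either double-bond geometry.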